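The compounds below may be only part of what the source reports. "The series", "measured", "known", "first", "only" and "open" are said of these compounds alone.

In a functional assay on SF-295 cells (Homo sapiens) for cytotoxicity, read by sulforhodamine B assay, with a stated time of 48 h (a higher number here means a weaker inhibitor of growth, a lower number a stronger inhibitor of growth), compound 1 (`COc1cc(C(=O)c2ccc(OC)c(O)c2OC)cc(OC)c1O`) gives 1400 nM and compound 2 (`COc1cc(C(=O)c2ccc3c(c2)oc(=O)n3S(C)(=O)=O)cc(OC)c1OC`) gives 1610 nM so the two stand within the usual scatter of each other. Compound 3 (`COc1ccc(C(=O)c2cc(OC)c(OC)c(OC)c2)c(OC)c1O`) follows from compound 1 through a single change, methyl in place of hydrogen on an oxygen on an aromatic ring, which reads as hydroxy to methoxy. Among the compounds with values here, no measured pair shows this change, so its size remains a judgement. A move to a lower number, beyond the scatter, is expected in this assay for this change (a 4.7-fold lower number from compound 1 to compound 3 (0.67 log units; beyond the scatter)). For compound 3 the estimated value is 300 nM with an expected range from 60 nM to 1500 nM on this read-out.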

Compound 3, concentration for 50% growth inhibition: 19.9 nM
Beside the measured number, compound 3's estimate is 15-fold (1.18 log units) above it; measured number below the stated range.
By their numbers in this assay, from the lowest: compound 3; then compounds 1 and 2 (each within the scatter of the next).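

Hydroxy to methoxy on this oxygen is the first single-place change in the series whose size can be read: in this assay the step is a 70-fold lower number from compound 1 to compound 3 (1.85 log units; beyond the scatter) and ranks as large. This position therefore responds strongly to the change, and growth inhibition here does not depend on the hydrogen of this hydroxy. Nothing measured here accounts for the size of the step.

From the compounds shown here alone, whether ethyl or a longer chain on this oxygen, or an amine in place of the methoxy, would hold the lower number remains open. A single pair also leaves open whether the step carries over to other cores.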